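Adding a chloro group to benzimidazoles tested on KB cells

The source may report more compounds than this note shows. Statements on the series, on what has been measured and on what is new or still open speak of the compounds shown alone.

Of the compounds shown here, three have been measured in a functional assay on KB cells (Homo sapiens) for inhibition; on this read-out higher numbers stand for weaker inhibition and lower numbers for stronger inhibition. Compound 1 `Nc1nc2cc(Cl)c(Cl)cc2n1Cc1ccc(Cl)cc1` carries one chloro group on its benzyl ring; in this assay compound 1 gives 45000 nM. Compound 2 `Nc1nc2cc(Cl)c(Cl)cc2n1Cc1ccc(Cl)c(Cl)c1` carries one more chloro group there, and compound 2 gives 35000 nM. The change from compound 1 to compound 2 is chloro in place of hydrogen on an aromatic carbon, and the step it made was a 1.3-fold lower number from compound 1 to compound 2 (0.11 log units; within the scatter).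

Compound 3 `Clc1cc2nc(Cl)n(Cc3ccccc3)c2cc1Cl` has a different core; how its core differs from that of compound 1 is not broken down here. For compound 3 this assay gave only a limit, > 100000 nM, not a number.

Compound 4 `Clc1cc2nc(Cl)n(Cc3ccccc3Cl)c2cc1Cl` is still to be measured. It differs from compound 3 by chloro in place of hydrogen on an aromatic carbon. Going by the values given here, this is the same kind of change as the one from compound 1 to compound 2, but not the same: there the chloro entered ortho to a chloro group and meta to a large group, whereas here it enters ortho to a large group.

The measured example of this change stayed within the scatter, so for compound 4 the expected step is a number no higher from compound 3 to compound 4 (the limit leaves the size open), and because the limit of > 100000 nM in this assay, at which 1 of the 3 values shown sits, already holds compound 3, the result for compound 4 is expected to be a limit as well in many runs. The estimate for compound 4 is 100000 nM, expected to fall between 40000 nM and 300000 nM.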

Compound 4, half-maximal inhibitory concentration: 156000 nM
Beside the measured number, compound 4's estimate is 1.6-fold (0.19 log units) below it, within the range that was stated.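

No size can be read for the step from compound 3 to compound 4, because compound 3 has only a limit and not a number in this assay: the limit of > 100000 nM in this assay, at which 1 of the 4 values shown sits.

The compounds shown leave open how far chloro in place of hydrogen on an aromatic carbon, ortho to a large group, shifts the result on the core shared by compound 3 and compound 4, and whether it would act alike on the core of compound 1.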